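A few compounds are considered here, and "the series" means these few. Any claim that something is new, unique, unknown or untested is made for them only; others in the source may bear on it.

Compounds measured so far:
compound 1 `Nc1ncc(-c2cnn(C3CCNCC3)c2)cc1-c1nc2ccc(-c3ccc4[nH]ncc4c3)cc2o1`, 1140 nM;
compound 2 `Nc1ncc(-c2cnn(C3CCNCC3)c2)cc1-c1nc2ccc(NC(=O)c3ccccc3)cc2o1`, 3490 nM.

Both compounds were tested in an assay on isolated protein for inhibition of G protein-coupled receptor kinase 5 (Homo sapiens), read by TR-FRET, with stated times of 10 min and 1 h; a lower number here means a stronger inhibitor, a higher number a weaker inhibitor. Compound 1 gives 1140 nM and compound 2 gives 3490 nM. Among the measured compounds shown here, compound 2 therefore has the highest of the two numbers, and its only neighbour is compound 1, with the step of a 3.1-fold higher number from compound 1 to compound 2 (0.49 log units; beyond the scatter) amounting to a modest weakening.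

Compound 3 `COc1ccc(-c2ccc3nc(-c4cc(-c5cnn(C6CCNCC6)c5)cnc4N)oc3c2)cc1` has not been measured. It differs from compound 2 by 4-methoxyphenyl in place of benzamido on an aromatic carbon. For the measured compounds named here, the one measured step that bears on this change is a 3.1-fold higher number from compound 1 to compound 2 (0.49 log units; beyond the scatter), in which an aryl ring bound straight to the core gave way to an amide-linked ring and the number rose. Compound 3 returns to a directly bound aryl ring, though one without the hydrogen-bond donor of the 1H-indazol-5-yl group of compound 1. On that basis the expectation is that compound 3 moves back toward compound 1, with an estimated step of a 2.3-fold lower number from compound 2 to compound 3 (0.37 log units; beyond the scatter) in this assay. For compound 3 the estimate in this assay is 1500 nM, with a range of 500 nM to 4500 nM.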

Compound 3, half-maximal inhibitory concentration: 3220 nM
Beside the measured number, compound 3's estimate is 2.1-fold (0.33 log units) below it, and the stated range covers the measured number.
By their numbers in this assay, from the lowest: compound 1; then compounds 3 and 2 (each within the scatter of the next).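

In this assay, 4-methoxyphenyl in place of benzamido on this aromatic carbon gives a 1.1-fold lower number from compound 2 to compound 3 (0.03 log units; within the scatter), so a ring bound straight to the core and an amide-linked ring cannot be told apart in this pair. Set against 1H-indazol-5-yl, the same group gives a 2.8-fold higher number from compound 1 to compound 3 (0.45 log units; beyond the scatter), which, like a 3.1-fold higher number from compound 1 to compound 2 (0.49 log units; beyond the scatter), lies beyond the scatter; compound 1 is thus the strongest inhibitor of the three, and among these compounds the lower number goes with 1H-indazol-5-yl rather than with direct attachment of an aryl ring. No measured evidence here accounts for this difference between the groups.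

Going by these compounds, what remains open is whether the lower number belongs specifically to the 1H-indazol-5-yl group, or whether rings such as 4-hydroxyphenyl, 4-aminophenyl or 1H-indol-5-yl on the same carbon would stand with compound 1 rather than with compound 2 and compound 3. On these data alone, it is also open whether any group at this position can bring the number well under that of compound 1, which gives 1140 nM.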